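One Tail Swapped for Another on the Shared Core

The compounds below may be only part of what the source reports. "The series", "measured", "known", "first", "only" and "open" are said of these compounds alone.

Three compounds share one core and differ only in the group hanging from a saturated chain. Compound 1 `N#CNC(=N)NCCCCCn1nc(-c2ccccc2)ccc1=O` gives 31% in a functional assay on the whole organism with Rattus norvegicus as the target, at a dose of 100 mg/kg; a lower number here means less inhibition, a higher number more inhibition at the dose given (going by the name of the read-out). Compound 2 `CN(C)/C(=N/CCCCn1nc(-c2ccccc2)ccc1=O)NC#N` gives 80.7% in this assay, and compound 3 `CC/N=C(\S)NCCCCCn1nc(-c2ccccc2)ccc1=O` gives 66.4%. Compound 3 therefore stands second highest of the three numbers: the step of a number 35.4 percentage points higher from compound 1 to compound 3 (beyond the scatter) sets it well above compound 1, while the step of a number 14.3 percentage points lower from compound 2 to compound 3 (beyond the scatter) leaves it below compound 2.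

Compound 4 `CC/N=C(/NC#N)NCCCCn1nc(-c2ccccc2)ccc1=O` has not yet been measured in this assay. It differs from compound 3 in one place: a group of 8 heavy atoms (4 carbon, 4 nitrogen; no ring) in place of a group of 7 heavy atoms (4 carbon, 2 nitrogen, 1 sulfur; no ring), on a saturated chain carbon, four bonds along the chain from an aromatic nitrogen. For the measured compounds named here, two measured steps bear on this change. The entering group closely resembles the group carried by compound 2, so running the step of a number 14.3 percentage points lower from compound 2 to compound 3 (beyond the scatter) backwards points to a modest rise. Against that, the step of a number 35.4 percentage points higher from compound 1 to compound 3 (beyond the scatter) showed that a sulfur-bearing group of this kind outscored a nitrogen-rich group of similar size, though on a longer chain and with a different partner on the nitrogen. Weighing both, a modest rise is expected, a number 5.6 percentage points higher from compound 3 to compound 4 (within the scatter). Compound 4 is estimated to give 72% in this assay, within a range of 50% to 90%.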

Compound 4, a percentage reported as inhibition, in the whole organism at one dose (the size of the read-out at that dose, not a potency): 58.8%
The estimate for compound 4 lay 13.2 percentage points above the measured number; the measured number falls inside the stated range.
By their numbers in this assay, from the lowest: compound 1; then compounds 4 and 3 (each within the scatter of the next); then compound 2.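

Exchanging the sulfur-bearing group for the nitrile-bearing one at this place gives a number 7.6 percentage points lower from compound 3 to compound 4 (within the scatter) in this assay, so this swap moves the number no further than repeat measurements would. Matching heavy atoms do not guarantee matching results, since the step of a number 21.9 percentage points lower from compound 2 to compound 4 (beyond the scatter) separates two groups of identical atom makeup, one with an ethyl on a nitrogen and the other with two methyls, while the step of a number 27.8 percentage points higher from compound 1 to compound 4 (beyond the scatter) shows that the ethyl-bearing group still scores clearly better than the smaller group of compound 1. No measurement offered here accounts for any of these differences, so the reason behind them remains unknown.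

The compounds shown leave open whether the rise seen with two methyls would continue with a larger group on that nitrogen, such as a piperidine ring, or would appear with a propyl group in place of the ethyl. They also leave open how a carboxylic acid or a simple amine would fare at this same place on the chain.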